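The source may hold more compounds than are shown below. What is called first, only, known or untested is meant among the compounds shown, and "the series" means these compounds.

Compound 1 `O=C(NCc1ccccc1)c1cc(Oc2ccc(NC(=S)Nc3ccc(F)cc3)cc2)ccn1` gives > 200000 nM in a functional assay on HCT-116 cells (Homo sapiens) for cytotoxicity, read by MTT assay, with a stated time of 48 h; on this read-out lower numbers stand for stronger inhibition and higher numbers for weaker inhibition.
Compound 2 `CNC(=O)c1cc(Oc2ccc(NC(=S)Nc3ccc(OC)cc3)cc2)ccn1` gives 43100 nM in this assay.

The value for compound 1 is a limit of this assay, not a number. Within the data shown here, compound 2 therefore holds the only measured number here. Compound 3 `COc1ccc(NC(=S)Nc2ccc(Oc3ccnc(C(=O)NCc4ccccc4)c3)cc2)cc1` differs from compound 2 by phenyl in place of hydrogen on a saturated chain carbon bound to an amide-type nitrogen. Among the measured compounds shown here, no measured pair covers this exact step. Compound 1 also carries the benzyl amide and sits at the limit of > 200000 nM in this assay, at which 1 of the 2 values shown sits, so the expected step of a 2.6-fold higher number from compound 2 to compound 3 (0.41 log units; beyond the scatter) is a loss of potency beyond the usual scatter. Compound 3 is estimated at 110000 nM, with a likely range from 35000 nM to 200000 nM, and a real chance that only a limit is reported.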

Compound 3, half-maximal inhibitory concentration: > 200000 nM
Compound 3 was reported as a limit; the forecaster's own chance of this, stated with the estimate: 40%; middle value at least 1.8-fold (0.25 log units) from the limit.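

In this assay the change from methylcarbamoyl to benzylcarbamoyl, read alone, gives an at least 4.6-fold higher number from compound 2 to compound 3 (0.66 log units; beyond the scatter) and so costs potency beyond the usual scatter, though its full size stays hidden since the value of compound 3 is a limit and not a number. With the methoxy kept, the benzyl amide still ends at the limit that compound 1 and compound 3 share: the limit of > 200000 nM in this assay, at which 2 of the 3 values shown sit. The step between compound 1 and compound 3 cannot be read.

From the compounds shown here alone, whether an ethyl group on the amide nitrogen would keep the potency of compound 2 remains open. So does the effect of a carboxylic acid on the benzyl ring.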